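Notes on swapping 3-nitrophenyl for 3,5-dimethoxyphenyl

A few compounds are considered here, and "the series" means these few. Any claim that something is new, unique, unknown or untested is made for them only; others in the source may bear on it.

Going by the values given here, in a functional assay on HepG2 cells (Homo sapiens) for cytotoxicity, read by MTT assay, with a stated time of 24 h (on this read-out lower numbers stand for stronger inhibition and higher numbers for weaker inhibition), compound 2 (`COc1cc(/C=C2\CN(S(=O)(=O)c3ccc(F)cc3)C/C(=C\c3cccc([N+](=O)[O-])c3)C2=O)cc(OC)c1OC`) gives 3250 nM, the lower of the two numbers so far, while compound 1 (`COc1cc(/C=C2\CN(S(=O)(=O)c3ccc(F)cc3)C/C(=C\c3cc(OC)cc(OC)c3)C2=O)cc(OC)c1`) gives 8100 nM. Compound 3 (`COc1cc(/C=C2\CN(S(=O)(=O)c3ccc(F)cc3)C/C(=C\c3cc(OC)c(OC)c(OC)c3)C2=O)cc(OC)c1`) departs from compound 2 by 3,5-dimethoxyphenyl in place of 3-nitrophenyl on a double-bonded chain carbon bound to a double-bonded ring carbon. The entering 3,5-dimethoxyphenyl also occurs in compound 1, which gives 8100 nM, so slightly weaker inhibition is the expected direction. The estimated step, a 1.5-fold higher number from compound 2 to compound 3 (0.19 log units; within the scatter), is small, toward a higher number and within the scatter. For compound 3 the expected value in this assay is 5000 nM, with an estimated range of 2200 nM to 11000 nM.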

Compound 3, half-maximal inhibitory concentration: 3890 nM
Compound 3: middle estimate off by 1.3-fold (0.11 log units), on the high side, and the stated range covers the measured number.
By their numbers in this assay, from the lowest: compounds 2 and 3 (each within the scatter of the next); then compound 1.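

In this assay, 3,5-dimethoxyphenyl in place of 3-nitrophenyl on a double-bonded chain carbon bound to a double-bonded ring carbon gives a 1.2-fold higher number from compound 2 to compound 3 (0.08 log units; within the scatter) and so does not separate the two groups at this position. Methoxy in place of hydrogen on an aromatic carbon gives a 2.1-fold lower number from compound 1 to compound 3 (0.32 log units; beyond the scatter) as a modest step, which is the one change here that moves the number beyond the scatter. Nothing at hand accounts for either step.

On these data alone, whether an amine or a carboxylic acid on this carbon would keep the number in the same range remains open. So does whether the methoxy step would recur with 3-nitrophenyl as the other aryl group.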